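Swapping the Triazole Substituent: What to Expect for Compound 4

This account rests on a few compounds, and the source may have more. Where it says the series, first, only, none or still open, it means among the compounds named here.

Measured so far in a functional assay on MCF7 cells (Homo sapiens) for inhibition, read by MTT assay, with a stated time of 24 h; on this read-out lower numbers stand for stronger inhibition and higher numbers for weaker inhibition:
- Compound 1 `CCOC(=O)C1=Cc2ccccc2OC1(OCc1cn(-c2ccc(F)cc2)nn1)C(F)(F)F` gives 9100 nM.
- Compound 2 `CCOC(=O)C1=Cc2ccccc2OC1(OCc1cc(-c2ccc(F)cc2F)no1)C(F)(F)F` reaches only a limit of the assay, > 150000 nM.
- Compound 3 `CCOC(=O)C1=Cc2ccccc2OC1(OCc1cn(-c2cccc(OC)c2)nn1)C(F)(F)F` also reaches only a limit of the assay, > 150000 nM.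

The three measured compounds share one core and differ only in the group attached to the five-membered ring. Among the measured compounds shown here, the single measured step between them, an at least 16-fold higher number from compound 1 to compound 3 (1.21 log units; beyond the scatter), runs toward weaker inhibition. As far as these compounds go, compound 3 therefore stands at the limit of > 150000 nM in this assay, at which 2 of the 3 values shown sit, so its true number is unknown beyond that boundary.

Compound 4 `CCOC(=O)C1=Cc2ccccc2OC1(OCc1cn(CC(=O)Nc2ccc(C)cc2)nn1)C(F)(F)F` differs from compound 3 by ((4-methylphenyl)carbamoyl)methyl in place of 3-methoxyphenyl on an aromatic nitrogen. For the measured compounds named here, no measured step covers this particular change; the one measured step only shows that the group on this aromatic nitrogen can shift the result by a large amount. From the compounds shown here alone, because compound 3 itself sits at the limit of > 150000 nM in this assay, at which 2 of the 3 values shown sit, a change in either direction remains open. Compound 4 is estimated at 80000 nM, within a range from 8000 nM to 300000 nM, which is expected to mean a step of an at least 1.8-fold lower number from compound 3 to compound 4 (0.27 log units; that floor lies within the scatter).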

Compound 4, half-maximal inhibitory concentration: > 150000 nM
Compound 4 gave a limit, no number (the forecaster's own chance of this, stated with the estimate: 50%); middle value at least 1.8-fold (0.27 log units) away from the limit.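

In this assay, compound 4 ends at a limit of the assay, as compound 3 does, so the steps between compounds at a limit cannot be read. Its ((4-methylphenyl)carbamoyl)methyl group differs clearly from the 3-methoxyphenyl of compound 3, as it carries a hydrogen-bond donor, yet replacing 4-fluorophenyl with it gives an at least 16-fold higher number from compound 1 to compound 4 (1.21 log units; beyond the scatter). Among the three groups shown on this aromatic nitrogen, only the 4-fluorophenyl of compound 1 therefore gives a readable number, and the assay's limit now dominates the series: the limit of > 150000 nM in this assay, at which 3 of the 4 values shown sit.

The compounds shown leave open how much of the activity of compound 1 depends on the fluorine itself, which a plain phenyl or a 4-chlorophenyl group would help to test. They also leave open whether a simple amine or carboxylic acid on a short chain at this nitrogen would give a readable number.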